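Methoxy Position Shift on a Terthiophene-Like Amidine: Hemolysis Estimate

This account rests on a few compounds, and the source may have more. Where it says the series, first, only, none or still open, it means among the compounds named here.

Compound 1 `N=C(N)c1ccc(-c2ccc(-c3ccccc3)s2)s1`: 56.7%
Compound 2 `COc1ccc(-c2ccc(-c3ccc(C(=N)N)s3)s2)cc1`: 63.7%

In an ADME assay on cells (Erythrocyte, Homo sapiens) for activation, read by hemolysis, with a stated time of 30 min, tested at 5 mM (a higher number here means a stronger effect of the compound at the concentration tested, a lower number a weaker effect), compound 1 gives 56.7%, the lower of the two numbers; compound 2 gives 63.7%, and the step of a number 7 percentage points higher from compound 1 to compound 2 (within the scatter) is within the scatter. Compound 3 `COc1cccc(-c2ccc(-c3ccc(C(=N)N)s3)s2)c1` differs from compound 1 by methoxy in place of hydrogen on an aromatic carbon. Among the compounds with values here, the only comparable step, a number 7 percentage points higher from compound 1 to compound 2 (within the scatter), places the same group elsewhere on the ring and stayed within the scatter, so no step beyond the scatter is expected in this assay. Compound 3 is estimated at 60%, between 45% and 75%. The expected step of a number 3.3 percentage points higher from compound 1 to compound 3 (within the scatter) is therefore small.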

Compound 3, a percentage reported as activity, at one concentration (the size of the read-out at that concentration, not a potency): 39%
Compound 3: middle estimate off by 21 percentage points, on the high side; measured number below the stated range.
By their numbers in this assay, from the lowest: compound 3; then compounds 1 and 2 (each within the scatter of the next).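

In this assay the step of a number 17.7 percentage points lower from compound 1 to compound 3 (beyond the scatter) shows that methoxy meta to a large group can move the number beyond the scatter, which the step of a number 7 percentage points higher from compound 1 to compound 2 (within the scatter) did not do. The same replacement of hydrogen on the six-membered aromatic ring of carbon only thus does not give the same result at every place. Nothing available gives a reason for this step. From the compounds shown here alone, whether a hydroxyl, a fluorine or an amine at this same place would also lower the number stays open.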